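The compounds below may be only part of what the source reports. "The series", "measured", "known", "first", "only" and "open" are said of these compounds alone.

Measured so far:
Compound 1 `Oc1ccccc1-c1cc(-c2ccc(C(F)(F)F)cc2)cc(-c2ccccc2O)n1`: in a functional assay on HeLa cells (Homo sapiens) for inhibition (on this read-out lower numbers stand for stronger inhibition and higher numbers for weaker inhibition), compound 1 gives only the assay limit > 50000 nM.
Compound 2 `Oc1cccc(-c2cc(-c3ccccc3C(F)(F)F)cc(-c3ccccc3O)n2)c1`: in this assay compound 2 gives 16800 nM.
Compound 3 `Oc1cccc(-c2cc(-c3ccc(C(F)(F)F)cc3)cc(-c3ccccc3O)n2)c1`: in this assay compound 3 gives only the assay limit > 50000 nM.

For the measured compounds named here, compound 2 holds the only number; the other two values sit at the limit of > 50000 nM in this assay, at which 2 of the 3 values shown sit. The change 3-hydroxyphenyl in place of 2-hydroxyphenyl on an aromatic carbon gives a step that the two limits leave unreadable from compound 1 to compound 3. From compound 2 to compound 3, 4-(trifluoromethyl)phenyl in place of 2-(trifluoromethyl)phenyl gives an at least 2.9-fold higher number from compound 2 to compound 3 (0.47 log units; beyond the scatter). How the cores of compound 1 and compound 2 differ is not broken down here.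

Compound 4 `Oc1cccc(-c2cc(-c3ccccc3C(F)(F)F)cc(-c3cccc(O)c3)n2)c1` is not yet measured. It differs from compound 2 by 3-hydroxyphenyl in place of 2-hydroxyphenyl on an aromatic carbon, the same kind of change as from compound 1 to compound 3, though the surroundings differ: in compound 2 the place is meta to a 2-(trifluoromethyl)phenyl group and meta to a 3-hydroxyphenyl group, in compound 1 meta to a 2-hydroxyphenyl group and meta to a 4-(trifluoromethyl)phenyl group. The earlier instance gives no readable size, so the expected step from compound 2 to compound 4 in this assay rests only on compound 2 at 16800 nM and is estimated as a 1.8-fold higher number from compound 2 to compound 4 (0.25 log units; within the scatter). Compound 4 is expected at 30000 nM, between 8000 nM and 100000 nM, with a fair chance of only a limit.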

Compound 4, half-maximal inhibitory concentration: 15200 nM
Compound 4: the middle estimate sits 2.0-fold (0.30 log units) above what was measured; the range from low to high includes it.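

In this assay, 3-hydroxyphenyl in place of 2-hydroxyphenyl on the core of compound 2 gives a 1.1-fold lower number from compound 2 to compound 4 (0.04 log units; within the scatter), so the two groups cannot be told apart on this core. For the compounds shown here, the same change from compound 1 to compound 3 cannot be read, and it offers no size to set beside this step: both values are limits, as the evidence records: the limit of > 50000 nM in this assay, at which 2 of the 4 values shown sit. Carrying the change between cores therefore remains untested, with only one readable instance.

Still open, from the compounds shown here alone, is how the change behaves on a core with 4-(trifluoromethyl)phenyl when a readable number is available. Going by these compounds, all four compounds carry hydroxyphenyl groups, so the effect of an amine or a carboxylic acid in place of the hydroxyl also remains open.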